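A few compounds are considered here, and "the series" means these few. Any claim that something is new, unique, unknown or untested is made for them only; others in the source may bear on it.

Working notes on the series.

Three compounds have numbers in a functional assay on BGC-823 cells (Homo sapiens) for antiproliferative activity, read by MTT assay, tested at 1 uM; on this read-out higher numbers stand for a stronger effect at the one concentration tested and lower numbers for a weaker effect. Compound 1 `COc1cc(C(=O)N/N=C/c2cccc(F)c2)cc(OC)c1OC` gives 13.6%. Compound 2 `COc1cc(C2=NN(C(C)=O)C(c3ccccc3C(F)(F)F)O2)cc(OC)c1OC` gives 31.8%. Compound 3 `COc1cc(C(=O)N/N=C/c2ccc(C(F)(F)F)cc2)cc(OC)c1OC` gives 47.4%. On these three numbers compound 2 stands second highest: its nearest neighbour is compound 3, higher by a margin beyond the scatter, and its furthest is compound 1, lower by a margin beyond the scatter. Among the compounds with values here, compounds 1 and 3 share one core and compound 2 another, so no single-change step between measured compounds is available.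

Compound 4 `COc1cc(C2=NN(C(C)=O)C(c3ccc(Cl)c([N+](=O)[O-])c3)O2)cc(OC)c1OC` is not yet measured in this assay. It differs from compound 2 in one place (4-chloro-3-nitrophenyl in place of 2-(trifluoromethyl)phenyl on a saturated ring carbon).

Within the data shown here, no measured step tells what this exchange does on the core of compound 2. The expected step from compound 2 to compound 4 is a number 3.2 percentage points higher from compound 2 to compound 4 (within the scatter), taken as within the scatter, with no direction claimed. On that basis compound 4 is expected to give about 35% in this assay, in a range from 15% to 60%.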

Compound 4, a percentage reported as inhibition, at one concentration (the size of the read-out at that concentration, not a potency): -2.3%
Compound 4: middle estimate off by 37.3 percentage points, on the high side, and the stated range ends above it.
By their numbers in this assay, from the lowest: compound 4; then compound 1; then compound 2; then compound 3.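

Within the data shown here, the exchange on the saturated ring carbon gives the first single-change reading on the core of compound 2: in this assay it produces a number 34.1 percentage points lower from compound 2 to compound 4 (beyond the scatter), so the read-out on this core depends on which aryl group sits at this position. Because the exchange alters both the substituents and their places on the aryl ring, this one step cannot be assigned to the chlorine, the nitro group or the loss of the trifluoromethyl group alone. Nothing shown bears on the cause of the step.

As far as these compounds go, it remains open whether a 4-chlorophenyl group or a 3-nitrophenyl group alone would carry the same step, and how an amine or a carboxylic acid on this aryl ring would read. From the compounds shown here alone, whether the same exchange would act alike on the core of compound 3 also stays open.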